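The source may hold more compounds than are shown below. What is called first, only, known or untested is meant among the compounds shown, and "the series" means these compounds.

Compound 1 `COc1ccc2[nH]c(C(=O)N3CC(=O)N(Cc4ccccc4)[C@@H](CN4CCC(C)CC4)C3)cc2c1`: > 30000 nM, a limit and not a number
Compound 2 `COc1ccc2[nH]c(C(=O)N3CC(=O)N(Cc4ccccc4)[C@@H](N4[C@H](C)CCC[C@@H]4C)C3)cc2c1`: 1400 nM
Compound 3 `COc1ccc2[nH]c(C(=O)N3CC(=O)N(Cc4ccccc4)[C@@H](CN4C(=O)c5ccccc5C4=O)C3)cc2c1`: 41000 nM

In an ADME assay on Vero cells (Chlorocebus sabaeus) for cytotoxicity, with a stated time of 7 days (a lower number here means that less compound is tolerated, a higher number that more compound is tolerated), compound 3 has the higher of the two true numbers, and the nearest is compound 2: a 29-fold higher number from compound 2 to compound 3 (1.47 log units; beyond the scatter). Compound 1 stands at a limit: the limit of > 30000 nM in this assay, at which 1 of the 3 values shown sits.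

Compound 4 `COc1ccc2[nH]c(C(=O)N3CC(=O)N(Cc4ccccc4)[C@@H](CN4CC5CC5C4)C3)cc2c1` is not yet measured. It differs from compound 3 as follows: a group of 6 heavy atoms (5 carbon, 1 nitrogen; one three-membered non-aromatic ring of carbon only, one five-membered non-aromatic ring with 1 hetero atom) in place of a group of 11 heavy atoms (8 carbon, 1 nitrogen, 2 oxygen; one five-membered non-aromatic ring with 1 hetero atom, one six-membered aromatic ring of carbon only), on a saturated chain carbon bound to a saturated ring carbon.

Going by the values given here, the only measured step at this same place is unreadable: a step that the limit leaves unreadable from compound 1 to compound 3. The large steps both involve compound 2, whose group sits on a saturated ring carbon instead: an at least 21-fold lower number from compound 1 to compound 2 (1.33 log units; beyond the scatter), and a 29-fold higher number from compound 2 to compound 3 (1.47 log units; beyond the scatter).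

Compound 4 keeps the chain carbon, so no step beyond the scatter is expected: a 1.4-fold lower number from compound 3 to compound 4 (0.14 log units; within the scatter). The estimate for compound 4 is 30000 nM, with an expected range of 10000 nM to 60000 nM.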

Compound 4, half-maximal cytotoxic concentration: 13800 nM
For compound 4 the middle estimate is 2.2-fold (0.34 log units) above the measured one; measured number inside the range.
By their numbers in this assay, from the lowest: compound 2; then compound 4; then compound 3.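

In this assay, a change of group on the saturated chain carbon now gives a readable step: a 3.0-fold lower number from compound 3 to compound 4 (0.47 log units; beyond the scatter). Compound 1 holds only a limit, and even so a second step at this place can be read: an at least 2.1-fold lower number from compound 1 to compound 4 (0.33 log units; beyond the scatter). The group on a saturated ring carbon still gives the lowest number: a 9.9-fold higher number from compound 2 to compound 4 (0.99 log units; beyond the scatter).

Open, on these data alone, is how a morpholine or a primary amine on the saturated chain carbon would stand. Also open, as far as these compounds go, is whether the place or the group itself sets the low number of compound 2.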